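This account rests on a few compounds, and the source may have more. Where it says the series, first, only, none or still open, it means among the compounds named here.

Compound 1 `CN(C)CCCCN(C(=O)O)c1ccccc1Cn1nc(-c2ccc(F)cc2)c2ccccc2c1=O` is tested in an ADME assay on Huh-7 cells (Homo sapiens) for cytotoxicity, read by MTT assay, with a stated time of 48 h (a lower number here means that less compound is tolerated, a higher number that more compound is tolerated), and gives 48500 nM. Compound 2 `CN(C)CCCCOC(=O)Nc1ccc(Cn2nc(-c3ccncc3)c3ccccc3c2=O)cc1` is measured in this assay and gives 62700 nM. Among the two numbers recorded, compound 2 has the highest, and its nearest neighbour is compound 1, whose number is lower by an amount that lies within the scatter, so the two cannot be told apart.

Compound 3 `COc1ccccc1-c1nn(Cc2ccc(NC(=O)OCCCCN(C)C)cc2)c(=O)c2ccccc12` has not yet been measured in this assay. It differs from compound 2 in one place: 2-methoxyphenyl in place of pyridin-4-yl on an aromatic carbon. Going by the values given here, no step between two measured compounds is available to guide the expectation, so only the two values of compound 1 and compound 2, both close together, can serve as anchors. On that basis a small step is expected from compound 2 to compound 3, of a 1.4-fold lower number from compound 2 to compound 3 (0.14 log units; within the scatter), likely toward a slightly lower number but not beyond the scatter. Compound 3 is therefore estimated to give 45000 nM in this assay, with a plausible range from 20000 nM to 95000 nM.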

Compound 3, half-maximal cytotoxic concentration: 44800 nM
Compound 3: middle estimate off by 1.0-fold (0.00 log units), on the high side; low and high end bracket the measured number.
By their numbers in this assay, from the lowest: compounds 3, 1 and 2 (each within the scatter of the next).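

In this assay, going by these compounds alone, the exchange of pyridin-4-yl for 2-methoxyphenyl gives a 1.4-fold lower number from compound 2 to compound 3 (0.15 log units; within the scatter) and so provides the first reading at this position, on the aromatic carbon next to the ring nitrogen. Replacing a ring with a hetero atom by a larger group with a ring of carbon only, and moving the single hydrogen-bond acceptor from the ring into the methoxy substituent, produces no difference that can be told from the scatter of this cytotoxicity measurement. Nothing in the available evidence accounts for this result, so it stands as an observation without an explanation.

Within the data shown here, the single step joins two changes, the loss of the ring nitrogen and the arrival of the methoxy group, and a plain phenyl at this carbon would be needed to separate them. On these data alone, it also remains open whether the same carbon would give a similar reading with a group of a different kind, such as an amine, a carboxylic acid or a longer alkyl chain.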